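A few compounds are considered here, and "the series" means these few. Any claim that something is new, unique, unknown or untested is made for them only; others in the source may bear on it.

Working notes on the series, read in a functional assay on L1210 cells (Mus musculus) for antiproliferative activity, with a stated time of 48 h; on this read-out higher numbers stand for weaker inhibition and lower numbers for stronger inhibition. Compound 1 `C=C(Br)C(=O)Nc1ccc(C(=O)/C=C/c2ccccc2)cc1` gives 880 nM, compound 2 `C=C(Br)C(=O)Nc1ccc(C(=O)/C=C/c2ccc(OC)cc2)cc1` gives 900 nM and compound 3 `C=C(Br)C(=O)Nc1ccc(C(=O)/C=C/c2ccc(OC)c(OC)c2)cc1` gives 1300 nM. Compound 2 therefore lies within the scatter of both other compounds, so the three values do not separate in this assay.

Compound 4 `C=C(Br)C(=O)Nc1ccc(C(=O)/C=C/c2ccc(OC)cc2OC)cc1` has not yet been measured. It differs from compound 2 by methoxy in place of hydrogen on an aromatic carbon, ortho to a large group and meta to a methoxy group.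

Two measured steps make the same kind of replacement: a 1.0-fold higher number from compound 1 to compound 2 (0.01 log units; within the scatter) and a 1.4-fold higher number from compound 2 to compound 3 (0.16 log units; within the scatter). Going by these compounds, both lie within the scatter, but neither places the methoxy ortho to a large group, so the new position remains untested. An expected step of a 1.1-fold higher number from compound 2 to compound 4 (0.05 log units; within the scatter) is estimated, with no change beyond the scatter. For compound 4 the expected value is 1000 nM, with an estimated range from 500 nM to 2200 nM.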

Compound 4, half-maximal inhibitory concentration: 520 nM
Estimate against measurement, compound 4: 1.9-fold (0.28 log units) above; measured number inside the range.
By their numbers in this assay, from the lowest: compounds 4, 1, 2 and 3 (each within the scatter of the next, the first and the last beyond it).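

In this assay, going by these compounds alone, methoxy placed ortho to a large group and meta to a methoxy group gives a 1.7-fold lower number from compound 2 to compound 4 (0.24 log units; within the scatter) and so adds a position that the earlier steps did not test, with no change that can be told from the scatter. The other methoxy addition gives a 1.4-fold higher number from compound 2 to compound 3 (0.16 log units; within the scatter) and points the opposite way, yet both steps stay within the scatter, so these numbers do not separate the two placements. No supporting measurement bears on this step, and the data offer no account of its direction.

Going by these compounds, it remains open whether an amine, a carboxylic acid or a longer alkoxy chain at this position would move the number beyond the scatter. Also open, on these data alone, is what this methoxy gives on the core of compound 1 without the methoxy already present in compound 2.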